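The source may report more compounds than this note shows. Statements on the series, on what has been measured and on what is new or still open speak of the compounds shown alone.

Measured compounds in a functional assay on KB cells (Homo sapiens) for inhibition; on this read-out higher numbers stand for weaker inhibition and lower numbers for stronger inhibition:
compound 1, `COc1ccc(Cn2c(Cl)nc3cc(Cl)c(Cl)cc32)cc1`, gives > 100000 nM
compound 2, `Cc1ccc(Cn2c(Cl)nc3cc(Cl)c(Cl)cc32)cc1`, gives > 100000 nM
compound 3, `COc1ccc(Cn2c(Br)nc3cc(Cl)c(Cl)cc32)cc1`, gives 55000 nM

The value of compound 1 is a limit of the assay, not a number. The value of compound 2 is likewise a limit, not a number. Among the compounds with values here, two of the three values sit at the limit of > 100000 nM in this assay, at which 2 of the 3 values shown sit, so compound 3 is the only compound with a number. From compound 1 to compound 3 the change is bromo in place of chloro on an aromatic carbon, and the step is an at least 1.8-fold lower number from compound 1 to compound 3 (0.25 log units; that floor lies within the scatter). From compound 1 to compound 2 the change is methyl in place of methoxy on an aromatic carbon, and the step is a step that the two limits leave unreadable from compound 1 to compound 2.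

Compound 4, `Cc1ccc(Cn2c(Br)nc3cc(Cl)c(Cl)cc32)cc1`, has not yet been measured in this assay. It differs from compound 3 by methyl in place of methoxy on an aromatic carbon, the same change as from compound 1 to compound 2, made here on the core of compound 3. That earlier step gives no readable size, so the expectation rests on compound 3 alone with its 55000 nM. Compound 4 is expected to give 80000 nM, estimated between 30000 nM and 200000 nM. The expected step is a 1.5-fold higher number from compound 3 to compound 4 (0.16 log units; within the scatter), with a real chance that the assay reports only a limit.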

Compound 4, half-maximal inhibitory concentration: > 100000 nM
Compound 4: a limit, no number; the forecaster's own chance of this, stated with the estimate: 50%; middle value at least 1.2-fold (0.09 log units) away from the limit.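

In this assay, the step for methyl in place of methoxy on the core of compound 3 is an at least 1.8-fold higher number from compound 3 to compound 4 (0.25 log units; that floor lies within the scatter). Compound 4 gives > 100000 nM, which is a limit and not a number. The other two steps cannot be read, so the size of this change on the core of compound 1 stays unknown, and the compounds neither confirm nor refute that it carries from one core to the other: the limit of > 100000 nM in this assay, at which 3 of the 4 values shown sit.

The compounds shown leave open how an amine or a carboxylic acid in place of methoxy would read in this assay. They also leave open what an ethoxy group or a longer chain would give on the core of compound 3.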